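The source may hold more compounds than are shown below. What is called first, only, known or untested is meant among the compounds shown, and "the series" means these compounds.

Measured so far in a functional assay on HCT-116 cells (Homo sapiens), read by crystal violet staining, with a stated time of 6 days; on this read-out lower numbers stand for stronger inhibition of growth and higher numbers for weaker inhibition of growth:
- compound 1 `COc1ccc([C@@H]2CC(=O)c3c(O)cc(OC(=O)c4ccccc4)cc3O2)cc1O` gives 16500 nM
- compound 2 `COc1ccc([C@@H]2CC(=O)c3c(O)cc(OC(=O)c4ccccc4C)cc3O2)cc1O` gives 22900 nM

Compound 2 at 22900 nM sits within the scatter of compound 1, and these two numbers are all the series offers so far. Next in line is compound 3 `COc1ccc([C@@H]2CC(=O)c3c(O)cc(OC(=O)C(C)(C)C)cc3O2)cc1O`, with the change tert-butyl in place of 2-methylphenyl on a carbonyl carbon on a carbonyl carbon whose other neighbours are: oxygen next to a carbonyl group. In words, this is tert-butyl in place of 2-methylphenyl.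

Among the compounds with values here, only one measured step bears on this, and only loosely. The step of a 1.4-fold higher number from compound 1 to compound 2 (0.14 log units; within the scatter) is methyl in place of hydrogen on an aromatic carbon and stays within the scatter. Within the data shown here, both measured compounds keep the aromatic ring at this place, so the data give no direct precedent for losing it. On the basis of compound 2 at 22900 nM and the small step of a 1.4-fold higher number from compound 1 to compound 2 (0.14 log units; within the scatter), no step beyond the scatter and no firm direction are expected in this assay, although the uncertainty is wide. The expected change is a 1.1-fold lower number from compound 2 to compound 3 (0.06 log units; within the scatter), as an estimate only. For compound 3 the estimated value is 20000 nM, with an expected range from 8000 nM to 50000 nM.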

Compound 3, concentration for 50% growth inhibition: 31500 nM
The estimate for compound 3 lay 1.6-fold (0.20 log units) below the measured number; the measured number falls inside the stated range.
By their numbers in this assay, from the lowest: compounds 1, 2 and 3 (each within the scatter of the next).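

In this assay, tert-butyl on the carbonyl carbon gives a 1.4-fold higher number from compound 2 to compound 3 (0.14 log units; within the scatter) against 2-methylphenyl and a 1.9-fold higher number from compound 1 to compound 3 (0.28 log units; within the scatter) against phenyl. Compound 1 and compound 2 both carry a six-membered aromatic ring at this place, so only compound 3 shows that a group with no ring, and with 4 heavy atoms in place of the 7 of 2-methylphenyl, still reads within the scatter of both aromatic groups. No independent measurement is available to explain this result.

As far as these compounds go, all three groups at this place are made of carbon only, so it remains open whether an amine, a carboxylic acid or a longer chain on the carbonyl carbon would give a step beyond the scatter. Within the data shown here, as no step so far lies beyond the scatter, no group at this position can yet be tied to stronger or weaker inhibition of growth in this assay.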